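The source may hold more compounds than are shown below. What is called first, only, known or untested is meant among the compounds shown, and "the series" means these compounds.

Measured so far:
compound 1 `Cc1nc(N)sc1CCCN/C(N)=N/C(=O)NCc1ccco1` — 10.5 nM
compound 2 `Cc1nc(N)sc1CCCN/C(N)=N/C(=O)NCc1ccccc1` — 69.2 nM

In an assay on membranes from Sf9 cells for displacement of a labelled ligand from histamine H2 receptor (Homo sapiens), read by scintillation counting, with a stated time of 60 min (a higher number here means a weaker inhibitor, a lower number a stronger inhibitor), compound 2 gives 69.2 nM, the higher of the two numbers; compound 1 gives 10.5 nM, and the step of a 6.6-fold higher number from compound 1 to compound 2 (0.82 log units; beyond the scatter) is the only one measured. Compound 3 `Cc1nc(N)sc1CCCN/C(N)=N/C(=O)NC(C)c1cccs1` has not been measured. It differs from compound 2 by 1-(thiophen-2-yl)ethyl in place of benzyl on an amide-type nitrogen.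

The change has two parts: the six-membered ring of carbon only gives way to a five-membered aromatic ring with one hetero atom, and a methyl branch appears on the chain carbon. Only the first part has a measured counterpart: the step of a 6.6-fold higher number from compound 1 to compound 2 (0.82 log units; beyond the scatter) shows that going from a five-membered hetero ring to phenyl raised the number, so the reverse direction in this assay should lower it. Going by the values given here, the hetero atom is different and the methyl branch has no measured counterpart, so the expected recovery is taken as partial. A step of a 3.1-fold lower number from compound 2 to compound 3 (0.50 log units; beyond the scatter) is expected, and compound 3 is estimated at 22 nM, with a range from 7 nM to 70 nM.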

Compound 3, inhibition constant: 63.1 nM
Compound 3: middle estimate off by 2.9-fold (0.46 log units), on the low side, within the range that was stated.
By their numbers in this assay, from the lowest: compound 1; then compounds 3 and 2 (each within the scatter of the next).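

In this assay, 1-(thiophen-2-yl)ethyl in place of benzyl on an amide-type nitrogen gives a 1.1-fold lower number from compound 2 to compound 3 (0.04 log units; within the scatter) and so leaves the two groups indistinguishable at this position; a five-membered aromatic ring with one hetero atom, when it comes together with a methyl branch on the chain carbon, does not bring the number to that of compound 1. Set directly against (furan-2-yl)methyl, the same group gives a 6.0-fold higher number from compound 1 to compound 3 (0.78 log units; beyond the scatter) and thus places compound 1 apart from both other compounds, while compound 2 and compound 3 stay together within the scatter. No evidence is at hand that bears on this result.

On these data alone, the ring change and the methyl branch are joined in compound 3, so their separate contributions remain open; (thiophen-2-yl)methyl, without the branch, and 1-(furan-2-yl)ethyl, with it, would divide the step into its two parts. Also open, as far as these compounds go, is whether the preference for (furan-2-yl)methyl holds with a longer chain between the amide-type nitrogen and the ring.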